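A few compounds are considered here, and "the series" means these few. Any claim that something is new, unique, unknown or untested is made for them only; others in the source may bear on it.

Compound 2 `Cc1ccc(Cl)cc1-n1nncc1CN1C(=O)C2(C(C#N)=C(N)Oc3c(N)cc4nc5ccccc5nc4c32)c2ccccc21` stands at the upper end of the two numbers recorded so far in a functional assay on MCF7 cells (Homo sapiens) for antiproliferative activity, read by MTT assay, with a stated time of 48 h (on this read-out lower numbers stand for stronger inhibition and higher numbers for weaker inhibition), where compound 2 gives 43500 nM. Going by the values given here, its only neighbour is compound 1 `N#CC1=C(N)Oc2c(N)cc3nc4ccccc4nc3c2C12C(=O)N(Cc1cnnn1-c1ccccc1Cl)c1ccccc12`, which in this assay gives 34400 nM, and the step of a 1.3-fold higher number from compound 1 to compound 2 (0.10 log units; within the scatter) lies within the scatter. The next compound, compound 3 `N#CC1=C(N)Oc2c(N)cc3nc4ccccc4nc3c2C12C(=O)N(Cc1cnnn1-c1ccc(Cl)cc1[N+](=O)[O-])c1ccccc12`, differs from compound 2 in one place: 4-chloro-2-nitrophenyl in place of 5-chloro-2-methylphenyl on an aromatic nitrogen. Among the compounds with values here, the one measured step that bears on this change sits on the same aromatic nitrogen, the step of a 1.3-fold higher number from compound 1 to compound 2 (0.10 log units; within the scatter), where 5-chloro-2-methylphenyl replaced 2-chlorophenyl and the number moved only within the scatter. On that single precedent, the expected step for compound 3 in this assay is a 1.1-fold lower number from compound 2 to compound 3 (0.04 log units; within the scatter), meaning no movement beyond the scatter in either direction. Compound 3 is therefore estimated at 40000 nM, with a likely range from 15000 nM to 110000 nM.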

Compound 3, half-maximal inhibitory concentration: > 50000 nM
Compound 3: no number, only a limit; the forecaster's own chance of this, stated with the estimate: 10%; at least 1.2-fold (0.09 log units) between middle value and limit.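

Compound 3 gives no number in this assay, only a limit: the limit of > 50000 nM in this assay, at which 1 of the 3 values shown sits. Read as floors, the change gives an at least 1.1-fold higher number from compound 2 to compound 3 (0.06 log units; that floor lies within the scatter) and an at least 1.4-fold higher number from compound 1 to compound 3 (0.16 log units; that floor lies within the scatter), so the true size of each step stays unknown, and it may be small or may lie beyond the scatter. Going by these compounds alone, the position therefore now holds a group, 4-chloro-2-nitrophenyl, that yields a limit where the two earlier groups yielded numbers, yet no step printed so far on this aromatic nitrogen lies beyond the scatter.

Still open, going by these compounds, is how far the true value of compound 3 lies from its limit. Also open, on these data alone, is whether a phenyl ring carrying an amine or a carboxylic acid in place of the nitro group would give a lower number on the same core.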